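The compounds below may be only part of what the source reports. "The series", "measured", "known", "first", "only" and "open" are said of these compounds alone.

Compounds measured so far:
compound 1, `C#CC(=O)Nc1ccc2c(c1)/C(=C/c1ccc[nH]1)C(=O)N2`, 340 nM
compound 2, `C=C(Br)C(=O)Nc1ccc2c(c1)CC(=O)N2`, 1100 nM
compound 3, `C=C(Br)C(=O)Nc1ccc2c(c1)/C(=C/c1ccc[nH]1)C(=O)N2`, 110 nM

All three were tested in a functional assay on Jurkat cells (Homo sapiens) for antiproliferative activity, read by MTT assay, with a stated time of 72 h; a higher number here means a weaker inhibitor, a lower number a stronger inhibitor. Compound 3 stands lowest of the three numbers: compound 1 is its nearest neighbour and compound 2 the furthest, and both gaps are beyond the scatter. Within the data shown here, the one step between compounds that differ in a single place is a 3.1-fold lower number from compound 1 to compound 3 (0.49 log units; beyond the scatter), and it concerns the group on the carbonyl carbon, not the part that changes next. Compound 4, `C=C(Br)C(=O)Nc1ccc2c(c1)/C(=C/c1ccc(C)s1)C(=O)N2`, differs from compound 3 in this way: 5-methylthiophen-2-yl in place of 1H-pyrrol-2-yl on a double-bonded chain carbon bound to a double-bonded ring carbon.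

Among the measured compounds shown here, no measured step bears on this exchange; the only guide is that the two compounds that carry the 1H-pyrrol-2-yl group, compounds 1 and 3, give the lower numbers, while compound 2 lacks that part altogether. The account therefore expects a modest rise, a 2.3-fold higher number from compound 3 to compound 4 (0.36 log units; beyond the scatter), with wide uncertainty. Compound 4 is estimated at 250 nM, within a range from 80 nM to 800 nM.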

Compound 4, half-maximal inhibitory concentration: 360 nM
For compound 4 the middle estimate is 1.4-fold (0.16 log units) below the measured one; low and high end bracket the measured number.
By their numbers in this assay, from the lowest: compound 3; then compounds 1 and 4 (each within the scatter of the next); then compound 2.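

In this assay, the exchange at this place, on a double-bonded chain carbon bound to a double-bonded ring carbon, gives a 3.3-fold higher number from compound 3 to compound 4 (0.51 log units; beyond the scatter). Among these compounds, this is the first measured sign that the number responds to which five-membered aromatic ring sits there, not only to the group on the carbonyl carbon. The exchange changes several things at once: the nitrogen gives way to sulfur, a methyl is added, and the hydrogen-bond donor of 1H-pyrrol-2-yl is gone, and no measurement here explains the rise.

The compounds shown leave open which of these changes goes with the higher number. As far as these compounds go, a thiophene without the methyl, or a phenyl ring at this place, would separate them, and whether any group here improves on 1H-pyrrol-2-yl remains unknown.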